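Phenyl for hydroxy on the anilide cap of compound 2

The source may report more compounds than this note shows. Statements on the series, on what has been measured and on what is new or still open speak of the compounds shown alone.

Measured compounds:
compound 1 `O=C(NO)c1ccc(CNc2nccc(-c3cccnc3)n2)cc1` — 410 nM
compound 2 `Nc1cc(O)ccc1NC(=O)c1ccc(CNc2nccc(-c3cccnc3)n2)cc1` — > 20000 nM

Compound 1 `O=C(NO)c1ccc(CNc2nccc(-c3cccnc3)n2)cc1` carries a hydroxamic acid and in an assay for inhibition of histone deacetylase 8 (Homo sapiens), read by fluorescence, with stated times of 15 min and 60 min (a lower number here means a stronger inhibitor, a higher number a weaker inhibitor), compound 1 gives 410 nM. Compound 2 `Nc1cc(O)ccc1NC(=O)c1ccc(CNc2nccc(-c3cccnc3)n2)cc1` carries instead a 2-amino-4-hydroxyphenyl on the amide-type nitrogen. For compound 2 this assay reports only a limit, > 20000 nM, and not a number; this is the limit of > 20000 nM in this assay, at which 1 of the 2 values shown sits. Within the data shown here, the one measured step, an at least 48-fold higher number from compound 1 to compound 2 (1.68 log units; beyond the scatter), therefore shows compound 2 standing at the weak end of what was measured, with no number to fix it more closely.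

Compound 3 `Nc1cc(-c2ccccc2)ccc1NC(=O)c1ccc(CNc2nccc(-c3cccnc3)n2)cc1` differs from compound 2 by phenyl in place of hydroxy on an aromatic carbon. Among the measured compounds shown here, no measured step touches this position: the step from compound 1 to compound 2 changed the group on the amide-type nitrogen, not the aromatic carbon that changes here. It gives only the starting point, a limit. Nothing shown points to a step in either direction beyond the scatter, and the estimated step is a step that the limit leaves unreadable from compound 2 to compound 3. Compound 3 is thus expected to give about 30000 nM, with a likely range from 8000 nM to 100000 nM, most probably again reported as a limit.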

Compound 3, half-maximal inhibitory concentration: > 20000 nM
Compound 3: only a limit was reported; the forecaster's own chance of this, stated with the estimate: 80%; the middle value lies beyond the limit too.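

In this assay compound 3 gives > 20000 nM, a limit and not a number. Among these compounds, compound 2 is also reported only as a limit, so no step between compound 2 and compound 3 can be read: the limit of > 20000 nM in this assay, at which 2 of the 3 values shown sit. The compounds shown leave open how weak compound 2 and compound 3 actually are, and whether phenyl or hydroxy on that aromatic carbon gives the stronger inhibitor.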